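Swapping one halogenated benzyl group for another

The source may hold more compounds than are shown below. What is called first, only, known or untested is meant among the compounds shown, and "the series" means these compounds.

Compound 1 `C=CCN1CCC(c2noc(COc3ccc(/C=C/C(=O)NO)cc3)n2)CC1` shows 66% in an assay on isolated protein for inhibition of protein deacetylase HDAC6 (Homo sapiens), read by fluorescence, with a stated time of 1 h, tested at 100 nM; on this read-out lower numbers stand for less inhibition and higher numbers for more inhibition at the one concentration tested (going by the name of the read-out). Compound 2 `O=C(/C=C/c1ccc(OCc2nc(C3CCN(Cc4ccc(F)c(F)c4)CC3)no2)cc1)NO` gives 60% in this assay; the step of a number 6 percentage points lower from compound 1 to compound 2 (within the scatter) leaves the two compounds within the usual scatter of each other, so neither can be called stronger. Compound 3 `O=C(/C=C/c1ccc(OCc2nc(C3CCN(Cc4ccccc4Cl)CC3)no2)cc1)NO` differs from compound 2 by 2-chlorophenyl in place of 3,4-difluorophenyl on a saturated chain carbon bound to an amine nitrogen in a ring. Going by the values given here, the only related step, at the same place, was a number 6 percentage points lower from compound 1 to compound 2 (within the scatter), so no change beyond the scatter is expected here, and the expected step is no change at the digits printed from compound 2 to compound 3 (within the scatter). Compound 3 is estimated at 60%, within a range of 45% to 75%.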

Compound 3, a percentage reported as inhibition, at one concentration (the size of the read-out at that concentration, not a potency): 59%
Estimate against measurement, compound 3: 1 percentage points above, and the stated range covers the measured number.
By their numbers in this assay, from the lowest: compounds 3, 2 and 1 (each within the scatter of the next).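

In this assay, the new compound adds a second halogenated phenyl to the comparison: 2-chlorophenyl in place of 3,4-difluorophenyl gives a number 1 percentage points lower from compound 2 to compound 3 (within the scatter), and 2-chlorophenyl in place of vinyl gives a number 7 percentage points lower from compound 1 to compound 3 (within the scatter). At this place, on a saturated chain carbon bound to an amine nitrogen in a ring, the read-out at its one concentration does not separate these three groups. Nothing available here offers an explanation for this result. Going by these compounds, whether a carboxylic acid or a longer chain at this place would move the number beyond the scatter remains open.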